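This account rests on a few compounds, and the source may have more. Where it says the series, first, only, none or still open, it means among the compounds named here.

Of the compounds shown here, three have been measured in a physicochemical assay for lipophilicity, read by HPLC, at pH 7.5; a higher number here means a more lipophilic compound, a lower number a more polar compound. Compound 1 `CC[C@@H](Nc1c(C#N)c(-c2ccc(-c3cccc(Cl)c3F)cc2)nc2cnccc12)C(N)=O` gives 3.1. Compound 2 `CC[C@@H](Nc1c(C#N)c(-c2ccc(-c3cccc(Cl)c3OC)cc2)nc2cnccc12)C(N)=O` carries methoxy in place of fluoro on an aromatic carbon and gives 3.1; that change made no change at the digits printed from compound 1 to compound 2 (within the scatter). Compound 3 `CC[C@@H](Nc1c(C#N)c(-c2ccc(-c3ccc(F)cc3)cc2)nc2cnccc12)C(N)=O` differs from compound 1 by 4-fluorophenyl in place of 3-chloro-2-fluorophenyl on an aromatic carbon. In this assay compound 3 gives 2.7, a step of a number 0.40 log units lower from compound 1 to compound 3 (beyond the scatter). Compound 4 `CC[C@@H](Nc1c(C#N)c(-c2ccc(-c3ccc(OC)cc3)cc2)nc2cnccc12)C(N)=O` has not yet been measured; it differs from compound 3 by methoxy in place of fluoro on an aromatic carbon. Going by the values given here, this is the same kind of change as the one from compound 1 to compound 2, but not the same change: in the earlier pair the place was ortho to a chloro group (1 heavy atom); ortho to a large group, whereas here it is para to a large group. Because no change at the digits printed from compound 1 to compound 2 (within the scatter) showed the exchange leaving the distribution coefficient where it stood, a similarly small step is expected for compound 4 in this assay, namely no change at the digits printed from compound 3 to compound 4 (within the scatter). Compound 4 is accordingly estimated at 2.7, with a likely range from 2.4 to 3.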

Compound 4, distribution coefficient: 2.7
Beside the measured number, compound 4's estimate shows no gap at the digits printed; the measured number falls inside the stated range.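

In this assay, methoxy in place of fluoro gave no change at the digits printed from compound 3 to compound 4 (within the scatter) and, on the chlorinated ring, no change at the digits printed from compound 1 to compound 2 (within the scatter), so the exchange left the reading where it stood in both settings on the shared core. Replacing the whole aryl group gave a number 0.40 log units lower from compound 2 to compound 4 (beyond the scatter) and, in the same way, a number 0.40 log units lower from compound 1 to compound 4 (beyond the scatter), so 4-methoxyphenyl stands apart from both chlorinated groups by a step of the same size as the one already seen for 4-fluorophenyl. These two pairs share one core and show nothing about how the exchange behaves on a different core, and nothing offered here accounts for the result.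

Still open, from the compounds shown here alone, is whether the same exchange would leave the reading in place on another core. Going by these compounds, it is also open whether a longer chain such as ethoxy, or an amine or a carboxylic acid, in the place of methoxy on this ring would do so.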